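Replacing a Carbamate with an Alkyl Group on the Piperidine Nitrogen

The compounds below may be only part of what the source reports. "The series", "measured", "known", "first", "only" and "open" are said of these compounds alone.

Of the compounds shown here, three have been measured in a functional assay on isolated protein for agonist activity at Glucose-dependent insulinotropic receptor (Homo sapiens), read by HTRF and cAMP accumulation; on this read-out lower numbers stand for an effect already at smaller amounts and higher numbers for an effect only at larger amounts of compound. Compound 1 `CC(C)(C)OC(=O)N1CCC(O[C@H]2CC[C@H](Oc3ccc(S(C)(=O)=O)cc3)CC2)CC1` gives 16.1 nM, compound 2 `Cc1nc(S(C)(=O)=O)ccc1O[C@H]1CC[C@H](OC2CCN(C(=O)OC(C)C)CC2)CC1` gives 11 nM, and compound 3 `CC1(OC(=O)N2CCC(O[C@H]3CC[C@H](Oc4cnc(S(C)(=O)=O)cn4)CC3)CC2)CC1` gives 25.9 nM. Compound 3 has the highest of the three numbers; its gap to compound 1 lies within the scatter, while compound 2 sits beyond the scatter with the lower number. Compound 4 `CS(=O)(=O)c1cnc(O[C@H]2CC[C@H](OC3CCN(CC4(C(F)(F)F)CC4)CC3)CC2)cn1` is not yet measured; it differs from compound 3 in one place: (1-(trifluoromethyl)cyclopropyl)methyl in place of ((1-methylcyclopropyl)oxy)carbonyl on an amine nitrogen in a ring. Among the compounds with values here, no measured pair shows a step of this kind, so the direction rests on the change alone. Compound 4 is expected to give 40 nM, with a range from 10 nM to 160 nM. This estimate means a step of a 1.5-fold higher number from compound 3 to compound 4 (0.19 log units; within the scatter), expected to be a modest loss, possibly not beyond the scatter.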

Compound 4, half-maximal effective concentration: 62.6 nM
For compound 4 the middle estimate is 1.6-fold (0.19 log units) below the measured one; low and high end bracket the measured number.
By their numbers in this assay, from the lowest: compounds 2, 1 and 3 (each within the scatter of the next, the first and the last beyond it); then compound 4.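

On an amine nitrogen in a ring, (1-(trifluoromethyl)cyclopropyl)methyl can stand in place of ((1-methylcyclopropyl)oxy)carbonyl, at the cost of a 2.4-fold higher number from compound 3 to compound 4 (0.38 log units; beyond the scatter), a modest step beyond the scatter. Within the data shown here, the activity thus survives at this position without the carbonyl, which none of the earlier compounds could show. No measurement shown bears on the cause of this loss. The compounds shown do not separate the loss of the carbonyl from the arrival of the trifluoromethyl. From the compounds shown here alone, an amide or a plain cyclopropylmethyl on the same nitrogen remains open.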